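The source may report more compounds than this note shows. Statements on the series, on what has been measured and on what is new or still open speak of the compounds shown alone.

Measured in a functional assay on HeLa cells (Homo sapiens) for inhibition; on this read-out higher numbers stand for weaker inhibition and lower numbers for stronger inhibition:
- compound 1 `Oc1ccc(-c2cc(-c3cccc(F)c3)cc(-c3ccccc3O)n2)cc1`: > 50000 nM
- compound 2 `Oc1ccc(-c2cc(-c3cccc(F)c3)cc(-c3cccc(O)c3)n2)cc1`: 14200 nM
- compound 3 `Oc1ccc(-c2cc(-c3cccc(F)c3)cc(-c3ccc(O)cc3)n2)cc1`: > 50000 nM

Compound 1 gives only a limit, > 50000 nM, and not a number. Compound 3 also gives only a limit, > 50000 nM. Compound 2 alone gives a number, 14200 nM.

Compound 4 `Oc1ccc(-c2cc(-c3ccccc3C(F)(F)F)cc(-c3ccccc3O)n2)cc1` keeps the 2-hydroxyphenyl group of compound 1 but carries 2-(trifluoromethyl)phenyl in place of 3-fluorophenyl, opposite the ring nitrogen (2-(trifluoromethyl)phenyl in place of 3-fluorophenyl on an aromatic carbon). The measured steps all change the hydroxyphenyl group instead, so none of them tests this position directly. Putting 3-hydroxyphenyl in place of 2-hydroxyphenyl gave an at least 3.5-fold lower number from compound 1 to compound 2 (0.54 log units; beyond the scatter). Putting 4-hydroxyphenyl in place of 3-hydroxyphenyl gave an at least 3.5-fold higher number from compound 2 to compound 3 (0.54 log units; beyond the scatter). The remaining step is a step that the two limits leave unreadable from compound 1 to compound 3. Only the compound with 3-hydroxyphenyl gave a number, and compound 4 does not have that group. No step beyond the scatter, in either direction, is therefore expected in this assay: the expected step is a number no higher from compound 1 to compound 4 (the limit leaves the size open). Compound 4 is estimated at 50000 nM, with an expected range of 15000 nM to 100000 nM.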

Compound 4, half-maximal inhibitory concentration: 16500 nM
For compound 4 the middle estimate is 3.0-fold (0.48 log units) above the measured one, and the stated range covers the measured number.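

Going by these compounds alone, putting 2-(trifluoromethyl)phenyl in place of 3-fluorophenyl, opposite the ring nitrogen, gave an at least 3.0-fold lower number from compound 1 to compound 4 (0.48 log units; beyond the scatter) in this assay, so this position, which no earlier step tested, does influence the read-out. The 3-hydroxyphenyl group of compound 2 is therefore not needed for a measurable number: the 2-hydroxyphenyl group stays in place in compound 4, which gives 16500 nM. The full size of the step stays unknown because compound 1 gives only a limit: the limit of > 50000 nM in this assay, at which 2 of the 4 values shown sit.

The change replaces both the substituent and its place on the phenyl ring, and the compounds shown cannot separate these two differences. Also open, as far as these compounds go, are how an amine or a carboxylic acid on that phenyl ring would read, and whether 2-(trifluoromethyl)phenyl would lower the number when combined with the 3-hydroxyphenyl group.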